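A few compounds are considered here, and "the series" means these few. Any claim that something is new, unique, unknown or untested is made for them only; others in the source may bear on it.

Series notes: three N-hydroxy amides on a shared core, compared in an ADME assay on microsomes from liver (Homo sapiens) for metabolic stability, read by LC-MS, using NADPH; a higher number here means that the compound lasts longer, a lower number that the compound disappears faster. Compound 1 (`CCC(C)(C)C(=O)N(O)Cc1ccc(F)c(F)c1F`) gives 0.882 h and compound 2 (`CCC(C)(C)C(=O)N(O)Cc1cc(F)c(F)c(F)c1`) gives 1.1 h, so these two lie within the scatter of each other. Compound 3 (`CCC(C)(C)C(=O)N(O)Cc1ccc(F)cc1`) gives 2.97 h, the highest half-life of the three, and both other compounds lie below it by more than the scatter.

Next is compound 4 (`CCC(C)(C)C(=O)N(O)Cc1ccc(F)c(F)c1`), not yet measured in this assay. It differs from compound 3 as follows: fluoro in place of hydrogen on an aromatic carbon. In words, this is fluoro in place of hydrogen on an aromatic carbon.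

Going by the values given here, no single-change step between measured compounds is available, so the expectation rests on a comparison across the three values. Compound 3, at 2.97 h, carries the fewest fluoro groups, while compound 1, at 0.882 h, and compound 2, at 1.1 h, carry more. Among the compounds with values here, no measured compound goes against this trend, though three compounds make a thin basis for it. Compound 4 carries an intermediate number of fluoro groups, so a fall of moderate size is expected, near the edge of the scatter. The expected step is a 1.9-fold lower number from compound 3 to compound 4 (0.27 log units; within the scatter). For compound 4 the estimated half-life is 1.6 h, with an expected range of 0.95 h to 2.8 h.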

Compound 4, half-life: 1.78 h
For compound 4 the middle estimate is 1.1-fold (0.05 log units) below the measured one, within the range that was stated.
By their numbers in this assay, from the lowest: compounds 1, 2, 4 and 3 (each within the scatter of the next, the first and the last beyond it).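

In this assay fluoro in place of hydrogen on an aromatic carbon, ortho to a fluoro group and meta to a large group, gives a 1.7-fold lower number from compound 3 to compound 4 (0.22 log units; within the scatter) and this single change therefore cannot be told apart from no change in half-life. The two single steps that put hydrogen in place of fluoro on an aromatic carbon, a 1.6-fold higher number from compound 2 to compound 4 (0.21 log units; within the scatter) and a 2.0-fold higher number from compound 1 to compound 4 (0.30 log units; within the scatter) also lie within the scatter, so compound 4 cannot be separated from any of the three compounds, and none of the single-fluoro steps available in this series is resolved. Nothing at hand bears on what lies behind these steps.

The compounds shown leave open how the half-life in this assay responds to anything other than fluoro or hydrogen on this six-membered aromatic ring, such as chloro, methoxy or a nitrile on the same aromatic carbon. Changes elsewhere on the shared core also remain open, for instance a longer chain in place of the branched alkyl group on the carbonyl.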